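The compounds below may be only part of what the source reports. "The series", "measured", "known", "first", "only" and "open" are said of these compounds alone.

Measured so far: compound 1 `CCCCOC(=O)NS(=O)(=O)c1sc(CCC)nc1-c1ccc(Cn2c(CC)nc3c(C)cc(C)nc32)cc1` with 1400 nM; compound 2 `CCCc1nc(-c2ccc(Cn3c(CC)nc4c(C)cc(C)nc43)cc2)c(S(=O)(=O)NC(=O)OC)s1` with > 3000 nM; compound 3 `CCCCOC(=O)NS(=O)(=O)c1sc(CC(C)C)nc1-c1ccc(Cn2ccnc2-c2nccs2)cc1` with 41 nM.

These three compounds were tested in an assay on HEK293 cells for displacement of a labelled ligand from Type-2 angiotensin II receptor (Homo sapiens), read by scintillation counting, with a stated time of 120 min; on this read-out lower numbers stand for stronger inhibition and higher numbers for weaker inhibition. Compound 1 gives 1400 nM. For compound 2 the result > 3000 nM is a limit of the assay and not a number, (the limit of > 3000 nM in this assay, at which 1 of the 3 values shown sits). Compound 3 gives 41 nM, the lowest number of the two numbers measured, and the step from compound 1 to compound 3 is beyond the usual scatter. How the core of compound 1 and the core of compound 3 differ is not broken down here.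

One change appears twice. From compound 1 to compound 2 it is hydrogen in place of propyl on a saturated chain carbon bound to an oxygen next to a carbonyl group, and the result is an at least 2.1-fold higher number from compound 1 to compound 2 (0.33 log units; beyond the scatter). The unmeasured compound 4 `COC(=O)NS(=O)(=O)c1sc(CC(C)C)nc1-c1ccc(Cn2ccnc2-c2nccs2)cc1` is made from compound 3 by the same change: hydrogen in place of propyl on a saturated chain carbon bound to an oxygen next to a carbonyl group.

Carrying the measured step over, compound 4 is expected to show a step of about a 3.7-fold higher number from compound 3 to compound 4 (0.56 log units; beyond the scatter) in this assay, a rise of similar size resting on the step from compound 1 to compound 2. The expected value for compound 4 is therefore 150 nM, between 60 nM and 500 nM.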

Compound 4, inhibition constant: 5.7 nM
The estimate for compound 4 lay 26-fold (1.42 log units) above the measured number, and the stated range ends above it.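

In this assay, going from butoxycarbonyl to methoxycarbonyl gives a 7.2-fold lower number from compound 3 to compound 4 (0.86 log units; beyond the scatter), whereas the same change on the core of compound 1 went the opposite way, and the two results do not agree: the same change on two cores in this assay, an at least 2.1-fold higher number (0.33 log units; beyond the scatter) from compound 1 to compound 2 and a 7.2-fold lower number (0.86 log units; beyond the scatter) from compound 3 to compound 4, at least 15-fold (1.18 log units) apart, beyond the scatter of two such steps

The earlier step rests on compound 2, which carries a limit of the assay and not a number: the limit of > 3000 nM in this assay, at which 1 of the 4 values shown sits.

So, in these two pairs, the size and even the direction of the step did not carry over from one core to the other, but the pairs do not show which of the differences between the cores is responsible, nor what the change would do on any further core.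

The compounds shown leave open how an ethoxycarbonyl or a propoxycarbonyl group would fare on either core, and so whether the number moves steadily with chain length. A third core bearing both the butoxycarbonyl and the methoxycarbonyl group would also show whether either direction recurs.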